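The source may report more compounds than this note shows. Statements on the series, on what has been measured and on what is new or still open speak of the compounds shown alone.

Among the compounds with values here, compound 3 `COc1cc(-c2ccnc3cc(-c4ccc(C(C)=O)cc4)nn23)cc(OC)c1OC` gives 1810 nM in a functional assay on HeLa cells (Homo sapiens) for inhibition, read by CCK-8 assay, with a stated time of 48 h (on this read-out higher numbers stand for weaker inhibition and lower numbers for stronger inhibition), and no measured compound gives a higher number. Compound 2 `COc1cc(-c2ccnc3cc(-c4ccc(Cl)cc4)nn23)cc(OC)c1OC` is indistinguishable from it within the scatter: compound 2 gives 1490 nM, and the step of a 1.2-fold higher number from compound 2 to compound 3 (0.08 log units; within the scatter). Compound 1 `COc1cc(-c2ccnc3cc(-c4ccc(C)cc4)nn23)cc(OC)c1OC` stands far away, since compound 1 gives 21 nM, the step of an 86-fold higher number from compound 1 to compound 3 (1.94 log units; beyond the scatter), and the step of a 71-fold higher number from compound 1 to compound 2 (1.85 log units; beyond the scatter).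

Compound 4 `COc1cc(-c2ccnc3cc(-c4ccc5ccn(C)c5c4)nn23)cc(OC)c1OC` is the next step from compound 3, with the change (1-methyl-1H-indol-6-yl in place of 4-acetylphenyl on an aromatic carbon). Within the data shown here, none of the measured steps makes this exchange: each of them only swaps one group on a simple aromatic ring, whereas here the whole 4-acetylphenyl leaves and a two-ring 1-methyl-1H-indol-6-yl enters. Among the measured compounds shown here, the measured compounds show only that a ring carrying a methyl, as in compound 1, gave a far lower number than rings carrying chloro or acetyl, as in compounds 2 and 3. The entering group carries a methyl and no acetyl, so the direction of change toward compound 1 seems plausible, but the size is uncertain. The expected step of a 7.2-fold lower number from compound 3 to compound 4 (0.86 log units; beyond the scatter) is therefore toward a lower number, beyond the scatter. Compound 4 is estimated to give about 250 nM, within a range from 25 nM to 2500 nM.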

Compound 4, half-maximal inhibitory concentration: 187 nM
Estimate against measurement, compound 4: 1.3-fold (0.13 log units) above; low and high end bracket the measured number.
By their numbers in this assay, from the lowest: compound 1; then compound 4; then compounds 2 and 3 (each within the scatter of the next).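

In this assay, this position on the shared core accepts a two-ring group in place of a single substituted phenyl ring: 1-methyl-1H-indol-6-yl in place of 4-acetylphenyl gives a 9.7-fold lower number from compound 3 to compound 4 (0.99 log units; beyond the scatter) and in place of 4-chlorophenyl gives an 8.0-fold lower number from compound 2 to compound 4 (0.90 log units; beyond the scatter) as the matching step. Yet the same group does not match the 4-methylphenyl group, and that exchange gives an 8.9-fold higher number from compound 1 to compound 4 (0.95 log units; beyond the scatter) in the opposite direction, so the indole compound sits between the methyl-bearing phenyl compound and the two weaker phenyl compounds, and a methyl on the entering group is not enough to reach the lowest number. Nothing shown here explains why these three steps take the sizes they do.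

From the compounds shown here alone, what a 1H-indol-6-yl group, with a hydrogen in place of the methyl on the ring nitrogen, would give remains open, so the share of this methyl in the result cannot be told. Also open, going by these compounds, is how an amine, a carboxylic acid or a longer alkyl chain on the phenyl ring would compare with the methyl, chloro and acetyl groups.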